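This account rests on a few compounds, and the source may have more. Where it says the series, first, only, none or still open, it means among the compounds named here.

Measured in an assay on cells for agonist activity at vitamin D3 receptor (Homo sapiens), with a stated time of 96 h; a higher number here means that more compound is needed for the effect, a lower number that less compound is needed:
- compound 1 `CCn1c(C(=O)NCCN(C)C)ccc1C(CC)(CC)c1ccc(OCCC(O)(CC)CC)c(C)c1` gives 82 nM
- compound 2 `CCN(CC)CCNC(=O)c1ccc(C(CC)(CC)c2ccc(OCCC(O)(CC)CC)c(C)c2)n1CC` gives 2.3 nM
- compound 3 `C=CCN(C)C(=O)c1ccc(C(CC)(CC)c2ccc(OCCC(O)(CC)CC)c(C)c2)n1CC` gives > 10000 nM

Compound 3 stands at the ceiling of this assay; its entry is a limit, not a number, as the limit of > 10000 nM in this assay, at which 1 of the 3 values shown sits, records. The two compounds with a number, compound 1 and compound 2, both carry a chain ending in a basic amine on the carbonyl carbon, and a 36-fold lower number from compound 1 to compound 2 (1.55 log units; beyond the scatter) separates them. Compound 3 carries allyl(methyl)amino there instead, and an at least 120-fold higher number from compound 1 to compound 3 (2.08 log units; beyond the scatter) and an at least 4300-fold higher number from compound 2 to compound 3 (3.63 log units; beyond the scatter) were both large losses.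

Compound 4 `CCC(C)C(NC(=O)c1ccc(C(CC)(CC)c2ccc(OCCC(O)(CC)CC)c(C)c2)n1CC)C(=O)OC` is the next step from compound 3: a group of 10 heavy atoms (7 carbon, 1 nitrogen, 2 oxygen; no ring) in place of a group of 5 heavy atoms (4 carbon, 1 nitrogen; no ring), on a carbonyl carbon. The entering group brings one hydrogen-bond donor and two acceptors where the leaving group had none, but it lacks the basic amine seen in compound 1 and compound 2, so neither measured step maps onto it directly. The two steps into compound 3 show that the group on the carbonyl carbon can swing this assay by a large margin, so a step beyond the scatter is expected here, most likely downward, though with wide uncertainty because compound 3 stands only at a limit (the limit of > 10000 nM in this assay, at which 1 of the 3 values shown sits). The expected step is an at least 20-fold lower number from compound 3 to compound 4 (1.30 log units; beyond the scatter). For compound 4 in this assay the estimate is 500 nM, with a range of 30 nM to 10000 nM.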

Compound 4, half-maximal effective concentration: > 10000 nM
Compound 4 gave a limit, no number (the forecaster's own chance of this, stated with the estimate: 25%); middle value at least 20-fold (1.30 log units) away from the limit.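

In this assay compound 4 gives > 10000 nM, which is a limit and not a number. Against the two compounds with a number, the group that compound 4 carries on the amide-type nitrogen gives an at least 4300-fold higher number from compound 2 to compound 4 (3.63 log units; beyond the scatter) and an at least 120-fold higher number from compound 1 to compound 4 (2.08 log units; beyond the scatter), so a larger group with hydrogen-bond donor and acceptor counts of its own does not bring back a measurable value here. The step between compound 3 and compound 4 cannot be read, but across the four compounds a value appears only with the dimethylamino or diethylamino chain end, and no compound shown goes against this, while two quite different groups on the carbonyl carbon now end at the same ceiling: the limit of > 10000 nM in this assay, at which 2 of the 4 values shown sit.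

As far as these compounds go, whether the amine nitrogen itself, its distance from the amide-type nitrogen or the size of its substituents decides the outcome stays open, and a pyrrolidine at the chain end, a longer chain or a hydroxyl in place of the amine would separate these. From the compounds shown here alone, whether a carboxylic acid in place of the ester of compound 4 gives a number also stays open.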